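The compounds below may be only part of what the source reports. "The series", "measured", "known", "first", "only" and "open" are said of these compounds alone.

Working notes on the series. Compound 1 `COc1ccc(CNC(=O)/C(C#N)=C/c2ccc(C)o2)cc1` and compound 2 `COc1ccc(CNC(=O)/C(C#N)=C/c2ccoc2)cc1` share one core and differ only in the ring carried by the double-bonded chain carbon. In a functional assay on DU-145 cells (Homo sapiens) for inhibition, read by MTT assay, with a stated time of 72 h (a lower number here means a stronger inhibitor of growth, a higher number a weaker inhibitor of growth), compound 1 gives 39000 nM, and compound 2 gives 7000 nM. Among the measured compounds shown here, the single measured step is a 5.6-fold lower number from compound 1 to compound 2 (0.75 log units; beyond the scatter). For the measured compounds named here, compound 2 therefore holds the lowest of the two numbers in this assay, with compound 1 as its only neighbour, a modest distance away.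

Compound 3 `COc1ccc(CNC(=O)/C(C#N)=C/c2ccc(Cl)cc2)cc1` is not yet measured. Its difference from compound 2 is 4-chlorophenyl in place of furan-3-yl on a double-bonded chain carbon bound to a double-bonded chain carbon. Going by the values given here, the measured step between compound 1 and compound 2 sits at the same place but swaps one five-membered ring for another, so it does not bear directly on the entry of a six-membered carbon-only ring carrying chlorine; it shows only that a change at this place can move this assay by a modest amount. Among the compounds with values here, with no closer precedent, the expected step of no change at the digits printed from compound 2 to compound 3 (within the scatter) is kept small, with no direction claimed beyond the scatter. Compound 3 is estimated at 7000 nM in this assay, with a range from 2000 nM to 25000 nM.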

Compound 3, concentration for 50% growth inhibition: 7000 nM
For compound 3 middle estimate and measured number coincide at the digits printed, within the range that was stated.
By their numbers in this assay, from the lowest: compounds 2 and 3 (each within the scatter of the next); then compound 1.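

At the double-bonded chain carbon, 4-chlorophenyl in place of furan-3-yl gives no change at the digits printed from compound 2 to compound 3 (within the scatter) in this assay, so this place accepts a six-membered aromatic ring of carbon only, carrying chlorine and lacking the ring oxygen, with the number held at the level of the furan-3-yl compound. Against 5-methylfuran-2-yl, 4-chlorophenyl gives a 5.6-fold lower number from compound 1 to compound 3 (0.75 log units; beyond the scatter) in this assay, the same size as a 5.6-fold lower number from compound 1 to compound 2 (0.75 log units; beyond the scatter) at this place, so among these three compounds the higher number belongs to compound 1 alone and does not follow ring size or the presence of a ring hetero atom. No measurement offered here explains why these rings give the numbers they do.

The step from compound 1 to compound 2 changes both the methyl group and the point of attachment of the furan ring, so furan-2-yl without the methyl group would be needed to separate the two. Also open, on these data alone, is how this assay responds at this place to an unsubstituted phenyl ring, a phenyl ring carrying an amine or a carboxylic acid, or a longer chain in place of the ring.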